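The compounds below may be only part of what the source reports. "The series", "measured", "known", "first", "only" and "open" are said of these compounds alone.

Compound 1 `O=C(O)CCc1ccc(OCc2ccc(Br)cc2)cc1` and compound 2 `O=C(O)CCc1ccc(OCc2ccc(Oc3ccccc3)cc2)cc1` share one core. For the measured compounds named here, in a functional assay on 1321-N1 cells for agonist activity at Free fatty acid receptor 1 (Homo sapiens), read by calcium flux (a higher number here means that more compound is needed for the effect, a lower number that less compound is needed), compound 1 gives 550 nM; in this assay compound 2 gives 204 nM, the lower of the two numbers, and the only step so far, a 2.7-fold lower number from compound 1 to compound 2 (0.43 log units; beyond the scatter), sets compound 2 apart from compound 1 beyond the scatter. Compound 3 `O=C(O)CCc1ccc(OCc2ccc(-c3ccccc3)cc2)cc1` carries phenyl in place of phenoxy on an aromatic carbon. Going by the values given here, no measured step covers a phenyl-for-phenoxy swap; the step from compound 1 to compound 2 shows only that a larger group at this position gave a modest gain, so an expected step of a 1.3-fold higher number from compound 2 to compound 3 (0.11 log units; within the scatter) in this assay seems plausible, within the scatter. Compound 3 is therefore estimated at 260 nM in this assay, with a range from 100 nM to 650 nM.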

Compound 3, half-maximal effective concentration: 912 nM
Compound 3: middle estimate off by 3.5-fold (0.55 log units), on the low side, and the stated range ends below it.
By their numbers in this assay, from the lowest: compound 2; then compounds 1 and 3 (each within the scatter of the next).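

In this assay, the step to phenyl gives a 4.5-fold higher number from compound 2 to compound 3 (0.65 log units; beyond the scatter), so the ring alone does not carry the gain seen with phenoxy at this position, para to a large group. With a 1.7-fold higher number from compound 1 to compound 3 (0.22 log units; within the scatter), phenyl stays within the scatter of bromo, and the aromatic ring adds nothing measurable over the halogen; among these three compounds, only phenoxy stands apart. No available measurement explains what the phenoxy oxygen contributes. Still open, going by these compounds, is whether an amine nitrogen in place of that oxygen, or a benzyloxy group at this position, would hold the lower number of compound 2.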